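Adding a carboxy group to a ketone-tetrazole FAAH inhibitor

The source may report more compounds than this note shows. Statements on the series, on what has been measured and on what is new or still open speak of the compounds shown alone.

Measured compounds:
compound 1 `CC(Oc1ccc(Oc2ccc(Cl)cc2)cc1)C(=O)Cn1nnc(-c2ccccc2)n1`: 51 nM
compound 2 `CC(Oc1ccc(-c2ccccc2)cc1)C(=O)Cn1nnc(-c2ccccc2)n1`: 15 nM

Of the compounds shown here, two have been tested in an assay on microsomes from brain for inhibition of Fatty-acid amide hydrolase 1 (Rattus norvegicus), read by fluorescence and HPLC, with a stated time of 60 min; a lower number here means a stronger inhibitor, a higher number a weaker inhibitor. Compound 1 gives 51 nM, the highest of the two numbers; its nearest neighbour is compound 2, and the step of a 3.4-fold lower number from compound 1 to compound 2 (0.53 log units; beyond the scatter) came with phenyl in place of 4-chlorophenoxy on an aromatic carbon.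

Compound 3 `CC(Oc1ccc(Oc2ccc(Cl)cc2)cc1)C(=O)Cn1nnc(-c2ccc(C(=O)O)cc2)n1` has not yet been measured. It keeps the whole of compound 1 and differs from it in one place: carboxy in place of hydrogen on an aromatic carbon. The new group sits on an aromatic carbon of a six-membered aromatic ring of carbon only, para to a large group, so that the phenyl on the tetrazole side becomes 4-carboxyphenyl.

Within the data shown here, no measured step touches this part of the molecule; the only known step, from compound 1 to compound 2, alters the opposite end. Among the measured compounds shown here, the expectation therefore rests on the single value of compound 1 alone and carries a wide range. Compound 3 is expected to give about 120 nM in this assay, somewhere between 30 nM and 500 nM. That estimate means a step of a 2.4-fold higher number from compound 1 to compound 3 (0.37 log units; beyond the scatter), expected to be a weakening that may or may not clear the scatter.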

Compound 3, half-maximal inhibitory concentration: 90 nM
For compound 3 the middle estimate is 1.3-fold (0.12 log units) above the measured one, and the stated range covers the measured number.
By their numbers in this assay, from the lowest: compound 2; then compounds 1 and 3 (each within the scatter of the next).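

In this assay the change from phenyl to 4-carboxyphenyl gives a 1.8-fold higher number from compound 1 to compound 3 (0.25 log units; within the scatter) and so cannot be told apart from the usual variation between repeat measurements. Among these compounds, this is the first information about this end of the molecule, as the earlier step changed only the opposite end: here a carboxy group, with its 3 heavy atoms, one hydrogen-bond donor and one hydrogen-bond acceptor, can replace a hydrogen on the aromatic carbon without a change in the number that clears the scatter. Nothing available accounts for this tolerance, so the result stands as an observation without an explanation.

Going by these compounds, whether the same holds for an amine or a methyl ester at this position, or for a longer chain ending in a carboxylic acid, remains open. Also open, on these data alone, is whether the carboxy group would be tolerated equally well on compound 2, which gives 15 nM and carries phenyl in place of 4-chlorophenoxy, since this single pair shows the change only with 4-chlorophenoxy present.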